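A few compounds are considered here, and "the series" means these few. Any claim that something is new, unique, unknown or untested is made for them only; others in the source may bear on it.

Measured so far in a functional assay on MDA-MB-231 cells (Homo sapiens) for inhibition; on this read-out lower numbers stand for stronger inhibition of growth and higher numbers for weaker inhibition of growth:

compound 1, `COc1cc(/C=C/C(=O)c2cccc(-n3cc(-c4ccccc4)[nH]c3=O)c2)cc(OC)c1OC` — 2170 nM
compound 2, `COc1ccc(-c2cn(-c3cccc(C(=O)/C=C/c4ccc(O)c(OC)c4)c3)c(=O)[nH]2)cc1` — 5250 nM

Compound 1 stands at the lowest of the two numbers in this assay. Compound 2 gives 5250 nM, a higher number than compound 1, and the gap between the two is beyond the usual scatter. Within the data shown here, the two compounds differ from each other in more than one place, so no single structural step links them, and the pair shows only what its two values show.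

Compound 3, `COc1cc(/C=C/C(=O)c2cccc(-n3cc(-c4cc(OC)c(OC)c(OC)c4)[nH]c3=O)c2)cc(OC)c1OC`, is the next compound for this assay. It differs from compound 1 in one place: 3,4,5-trimethoxyphenyl in place of phenyl on an aromatic carbon. Among the measured compounds shown here, no measured step of this kind exists, so the size and direction of the change rest on compound 1 alone. Given that compound 1 gives 2170 nM, the step from compound 1 to compound 3 is expected to be small, a 1.4-fold lower number from compound 1 to compound 3 (0.13 log units; within the scatter), with no confident direction beyond the scatter. For compound 3 the estimated value in this assay is 1600 nM, with a range from 500 nM to 5000 nM.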

Compound 3, concentration for 50% growth inhibition: 4190 nM
Compound 3: the middle estimate sits 2.6-fold (0.42 log units) below what was measured; the range from low to high includes it.
By their numbers in this assay, from the lowest: compounds 1, 3 and 2 (each within the scatter of the next, the first and the last beyond it).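

Among these compounds, replacing phenyl with 3,4,5-trimethoxyphenyl on this aromatic carbon of the five-membered aromatic ring with 2 nitrogen gives the first one-place step, read in this assay as a 1.9-fold higher number from compound 1 to compound 3 (0.29 log units; within the scatter) and so not separating the two groups on this read-out. Compound 1 and compound 3 therefore show that this carbon can carry the larger 3,4,5-trimethoxyphenyl group, with its added oxygen atoms, without a change beyond the scatter in growth inhibition, which the earlier pair, differing in more than one place, could not show. No measured evidence on the compounds accounts for this result, so the step stands as an observation only.

A single step with the core of compound 1 held fixed says nothing about how the same exchange would read with a different group at the other end of the molecule, so its size may not carry over. Also open, as far as these compounds go, is whether a basic amine, such as an aminomethyl group, or a carboxylic acid on the phenyl ring at this carbon would produce a step beyond the scatter.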